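This account rests on a few compounds, and the source may have more. Where it says the series, first, only, none or still open, it means among the compounds named here.

Going by the values given here, compound 2 `CC1=C(N2CC2)C(=O)C(CCC(=O)N(C)C)=C(N2CC2)C1=O` stands at the top of the two numbers measured so far in a functional assay on L1210 cells (Mus musculus), with a stated time of 1 days (on this read-out lower numbers stand for lower potency and higher numbers for higher potency (the scale is a negative logarithm)), where compound 2 gives 4.84. Its nearest neighbour is compound 1 `CC1=C(N2CC2)C(=O)C(Cc2ccccc2)=C(N2CC2)C1=O`, which in this assay gives 4.26. Among the compounds with values here, the single measured step runs between these two: a number 0.58 log units higher from compound 1 to compound 2 (beyond the scatter). The compound still to be measured, compound 3 `CCC(OC)C1=C(N2CC2)C(=O)C(C)=C(N2CC2)C1=O`, differs from compound 2 in one place: 1-methoxypropyl in place of 2-(dimethylcarbamoyl)ethyl on a double-bonded ring carbon. The 2-(dimethylcarbamoyl)ethyl chain leaves and 1-methoxypropyl enters. The measured step from compound 1 to compound 2 bears on this only loosely, since it concerns the exchange of phenyl for a dimethylcarbamoyl-bearing group rather than the present pair; still, it shows that bringing in the dimethylcarbamoyl group went along with a modest gain, and taking it away again may hand part of that gain back. A small downward step is therefore expected, a number 0.34 log units lower from compound 2 to compound 3 (beyond the scatter), though it could well fall within the scatter. Compound 3 is thus estimated to give 4.5 in this assay, with a range from 3.9 to 5.1.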

Compound 3, logarithm of the reciprocal of the active concentration, log(1/C): 4.84
Estimate against measurement, compound 3: 0.34 log units below; the measured number falls inside the stated range.
By their numbers in this assay, from the lowest: compound 1; then compounds 2 and 3 (each within the scatter of the next).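

In this assay, the ring carbon that carried 2-(dimethylcarbamoyl)ethyl in compound 2 accepts a quite different side chain, 1-methoxypropyl, with no change at the digits printed from compound 2 to compound 3 (within the scatter), so the dimethylcarbamoyl group is not needed to reach this level; an amide nitrogen is absent from compound 3, and the chain has 5 heavy atoms rather than 7. The comparison with the benzyl compound gives a number 0.58 log units higher from compound 1 to compound 3 (beyond the scatter), so among these three compounds, the two with a side chain carrying no ring both stand above the one with benzyl, with no compound going against this, though three compounds make only a thin pattern. Nothing measured here explains why these side chains compare as they do.

From the compounds shown here alone, both ring-free chains carry an oxygen, so it remains open whether that atom matters, and a plain propyl chain with no oxygen would speak to this directly. Going by these compounds, it is also open how far this tolerance extends, for instance to a chain ending in a carboxylic acid or an amine, or to a longer chain.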